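This account rests on a few compounds, and the source may have more. Where it says the series, first, only, none or still open, it means among the compounds named here.

Measured compounds:
compound 1 `Cn1ncnc1-c1cc(Oc2ccc(NC(=O)N/N=C/c3ccccc3)cc2F)ccn1` — > 100000 nM
compound 2 `CN(C)CCn1cnnc1-c1cc(Oc2ccc(NC(=O)N/N=C/c3ccc(O)c(O)c3)cc2F)ccn1` — > 100000 nM

Of the compounds shown here, two have been tested in a functional assay on A549 cells (Homo sapiens) for cytotoxicity, read by MTT assay, with a stated time of 72 h; on this read-out lower numbers stand for stronger inhibition and higher numbers for weaker inhibition. Compound 1 gives > 100000 nM, which is a limit of the assay rather than a number. Compound 2 likewise gives > 100000 nM, again a limit and not a measured value. Compound 2 therefore stands at the limit of > 100000 nM in this assay, at which 2 of the 2 values shown sit, and nothing in these two values tells the compounds apart.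

Compound 3 `Cc1cc(/C=N/NC(=O)Nc2ccc(Oc3ccnc(-c4nncn4CCN(C)C)c3)c(F)c2)cc(C)c1O` is not yet measured. It differs from compound 2 in one place: 4-hydroxy-3,5-dimethylphenyl in place of 3,4-dihydroxyphenyl on a carbon with a double bond to nitrogen. Among the compounds with values here, no pair of measured compounds differing in a single place is available, so there is no measured step to lean on, and the change is judged on its own. In this assay the step from compound 2 to compound 3 is expected to be none beyond the scatter, since compound 2 sits at a limit and the change is confined to one ring substituent. Compound 3 is therefore expected to give 100000 nM, with a plausible range from 30000 nM to 300000 nM. The step this estimate implies is a number no higher from compound 2 to compound 3 (the limit leaves the size open), and most likely only a limit will be reported again.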

Compound 3, half-maximal inhibitory concentration: 1640 nM
Compound 3: middle estimate off by 61-fold (1.79 log units), on the high side; the whole stated range lies above it.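

In this assay, the ring on the carbon with a double bond to nitrogen proves able to move the result: 4-hydroxy-3,5-dimethylphenyl in place of 3,4-dihydroxyphenyl gives an at least 60-fold lower number from compound 2 to compound 3 (1.78 log units; beyond the scatter), and this is the only true number among the compounds shown. The swap changes several things at once, as one hydroxyl group leaves and two methyl groups enter, so this single step cannot assign the effect to either change alone. The true size of the step remains open-ended because compound 2 has only a limit, not a number: the limit of > 100000 nM in this assay, at which 2 of the 3 values shown sit.

The compounds shown leave open whether the drop needs the loss of the hydroxyl group, the presence of the two methyl groups, or both, and a ring carrying chlorine atoms or methoxy groups in place of the methyl groups would help to separate these possibilities. They also leave open why this change alters the result in these cells, since nothing here measures a cause.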